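Halogen swap on the fused core: chloro to fluoro

The source may report more compounds than this note shows. Statements on the series, on what has been measured and on what is new or still open speak of the compounds shown alone.

Measured compounds in an assay on isolated protein for binding affinity to Alpha-1D adrenergic receptor (Rattus norvegicus), read by radioligand binding; a lower number here means a stronger inhibitor, a higher number a weaker inhibitor:
- compound 1, `CS(=O)(=O)Nc1ccc(Cl)c2c1CCCC2c1c[nH]cn1`: 2880 nM
- compound 2, `CCS(=O)(=O)Nc1cccc2c1CCCC2(O)c1c[nH]cn1`: < 10000 nM
- compound 3, `CCS(=O)(=O)Nc1cccc(C2CCNC2)c1`: 1000 nM

Of the two plain numbers in this assay, compound 1 has the higher one, 2880 nM, so it is the weaker inhibitor of the two. Compound 3 gives 1000 nM, and the gap between compound 3 and compound 1 lies beyond the usual scatter. The value of compound 2, < 10000 nM, is a limit of the assay rather than a number; (the limit of < 10000 nM in this assay, at which 1 of the 3 values shown sits).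

Compound 4, `CS(=O)(=O)Nc1ccc(F)c2c1CCCC2c1c[nH]cn1`, is the next member of the series and differs from compound 1 in one place only: fluoro in place of chloro on an aromatic carbon. The chloro of compound 1 leaves and a fluoro enters at the same aromatic carbon of the fused core.

Among the compounds with values here, no pair of measured compounds here shows this kind of change, so the expectation rests on compound 1 alone. The step of a 1.2-fold higher number from compound 1 to compound 4 (0.08 log units; within the scatter) is expected to be small, within or only just beyond the scatter, with no firm direction. Compound 4 in this assay is estimated at 3500 nM, with a likely range from 1200 nM to 10000 nM.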

Compound 4, inhibition constant: 3020 nM
Estimate against measurement, compound 4: 1.2-fold (0.06 log units) above, within the range that was stated.
By their numbers in this assay, from the lowest: compound 3; then compounds 1 and 4 (each within the scatter of the next).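

In this assay, fluoro in place of chloro on this aromatic carbon, para to a methanesulfonamido group, gives a 1.0-fold higher number from compound 1 to compound 4 (0.02 log units; within the scatter) and so leaves the two halogens indistinguishable at this position of the shared core. Within the data shown here, this is the first step that can be read between compounds differing in one place, and it indicates that the affinity seen here does not depend on chloro specifically, at least when the replacement is fluoro. Nothing in the data shown accounts for this step, so it stands as an observation without a stated cause.

Going by these compounds, whether a larger or different group on the same carbon, such as methoxy, a nitrile or an amine, would stay within the scatter of these two halogens remains open, as does the effect of plain hydrogen there. Compound 2 and compound 3 each differ from compound 1 in more than one place, so their steps cannot be read, and the contributions of the other parts of the core stay unresolved.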